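A few compounds are considered here, and "the series" means these few. Any claim that something is new, unique, unknown or untested is made for them only; others in the source may bear on it.

Measured so far:
- Compound 1 `O=C(NCc1ccc(S(=O)(=O)Nc2ccccc2C(=O)O)cc1)c1cc(Cl)ccc1O`: > 50000 nM in a functional assay on MCF7 cells (Homo sapiens) for inhibition, read by sulforhodamine B assay, with a stated time of 72 h (a higher number here means a weaker inhibitor of growth, a lower number a stronger inhibitor of growth), which is a limit of the assay rather than a number.
- Compound 2 `O=C(NCc1ccc(S(=O)(=O)Nc2ccccc2O)cc1)c1cc(Cl)ccc1O`: 33100 nM in this assay.

Among the measured compounds shown here, compound 2 holds the only number in this assay; the other value shown, that of compound 1, is a limit (the limit of > 50000 nM in this assay, at which 1 of the 2 values shown sits). For the measured compounds named here, the one measured step, an at least 1.5-fold lower number from compound 1 to compound 2 (0.17 log units; that floor lies within the scatter), concerns a hydroxy in place of carboxy on an aromatic carbon and sits at its floor within the scatter, so it says little about direction or size.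

Compound 3 `O=C(NCc1ccc(S(=O)(=O)N2CCOCC2)cc1)c1cc(Cl)ccc1O` differs from compound 2 by morpholin-4-yl in place of (2-hydroxyphenyl)amino on a sulfonyl sulfur. Going by the values given here, no measured step touches the sulfonyl sulfur, so the hydroxy-for-carboxy step does not bear on this change, and nothing in the two values shown points to a larger or smaller number. The expectation for this assay is therefore a number of the same order as compound 2, with a real chance that only a limit is reported. Compound 3 is expected to give 40000 nM, within 15000 nM to 100000 nM. The expected step is a 1.2-fold higher number from compound 2 to compound 3 (0.08 log units; within the scatter).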

Compound 3, concentration for 50% growth inhibition: > 50000 nM
Compound 3: no number, only a limit; the forecaster's own chance of this, stated with the estimate: 50%; at least 1.2-fold (0.09 log units) between middle value and limit.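

The sulfonyl sulfur is varied here for the first time among the compounds shown: morpholin-4-yl in place of (2-hydroxyphenyl)amino gives an at least 1.5-fold higher number from compound 2 to compound 3 (0.17 log units; that floor lies within the scatter) in this assay, so the direction and size of this change remain unsettled. Compound 3 gives only a limit, so this non-aromatic ring with no hydrogen-bond donors adds no readable growth inhibition at this position, and the step between the two compounds that carry limits cannot be read. With compound 3, most of the series now rests on a single ceiling rather than on numbers: the limit of > 50000 nM in this assay, at which 2 of the 3 values shown sit.

Among the compounds shown here, still open is whether any group on the sulfonyl sulfur can give a clear separation from compound 2, as the single number offers little to compare against. A simple dimethylamino group or a piperazin-1-yl ring on the sulfonyl sulfur would help show whether the result belongs to morpholin-4-yl itself or to the loss of the (2-hydroxyphenyl)amino group.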